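The compounds below may be only part of what the source reports. "The series", "measured", "known", "first", "only" and "open" are said of these compounds alone.

Measured compounds:
compound 1, `COc1ccc(/C=C/C(=O)c2ccccc2-c2ccc(F)cc2)cc1O` — in a functional assay on HCT-8 cells (Homo sapiens) for antiproliferative activity, read by sulforhodamine B assay, with a stated time of 48 h (a higher number here means a weaker inhibitor, a lower number a stronger inhibitor), compound 1 gives 38 nM
compound 2, `COc1ccc(/C=C/C(=O)c2ccccc2-c2ccc(F)cc2)cc1B(O)O` — in this assay compound 2 gives 63 nM

Compound 1 serves as the point of reference. Among the measured compounds shown here, its only measured companion is compound 2, and the step of a 1.7-fold higher number from compound 1 to compound 2 (0.22 log units; within the scatter) is within the scatter, so the two numbers cannot be told apart on this evidence.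

Compound 3, `COc1ccc(/C=C/C(=O)c2ccccc2-c2cccc(F)c2)cc1O`, differs from compound 1 in a single way: 3-fluorophenyl in place of 4-fluorophenyl on an aromatic carbon. The fluorine-bearing ring keeps its atoms and changes only the position of the fluorine on that ring. For the measured compounds named here, the one measured step, from compound 1 to compound 2, alters a different part of the molecule, the group on the other ring, and therefore says nothing directly about moving the fluorine. Going by the values given here, there is no measured pair in which 3-fluorophenyl replaces 4-fluorophenyl, so the expectation rests on the small size of the change alone.

Compound 3 is therefore expected to give a number close to that of compound 1, with a step of a 1.3-fold higher number from compound 1 to compound 3 (0.10 log units; within the scatter) that is expected to fall within the scatter. For compound 3 the estimate in this assay is 48 nM, expected to lie between 15 nM and 150 nM.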

Compound 3, half-maximal inhibitory concentration: 16 nM
The estimate for compound 3 lay 3.0-fold (0.48 log units) above the measured number, within the range that was stated.
By their numbers in this assay, from the lowest: compound 3; then compounds 1 and 2 (each within the scatter of the next).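

In this assay the place of the fluorine on this ring proves to count: the step is a 2.4-fold lower number from compound 1 to compound 3 (0.38 log units; beyond the scatter) and, though modest, it lies beyond the scatter, even though 3-fluorophenyl and 4-fluorophenyl have the same atoms and the same counts of hydrogen-bond donors and acceptors. Among the compounds shown here, the earlier step, a 1.7-fold higher number from compound 1 to compound 2 (0.22 log units; within the scatter), changed a group on the other ring and stayed within the scatter, so the fluorine-bearing ring, ortho to a large group, is the first place in this small set where a change moves the number measurably. No evidence at hand accounts for this difference, and a single pair cannot establish a wider trend.

What the compounds shown leave open is whether a chlorine atom, a methoxy group or a trifluoromethyl group on this ring would give a lower or a higher number than the fluorine does, and whether a plain phenyl ring would retain the activity. They also leave open whether 3-fluorophenyl would give a similar step when paired with the boronic acid of compound 2 rather than the hydroxyl group of compound 1.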